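The source may report more compounds than this note shows. Statements on the series, on what has been measured and on what is new or still open speak of the compounds shown alone.

Measured so far in a functional assay on HL-60 cells (Homo sapiens) for antiproliferative activity, read by MTT assay, with a stated time of 72 h; on this read-out lower numbers stand for stronger inhibition and higher numbers for weaker inhibition:
- compound 1 `CC(C)(C)c1ccc(OCCCON2C(N)=NC(N)=NC23CCSCC3)cc1`: 280 nM
- compound 2 `NC1=NC2(CCSCC2)N(OCCCOc2ccc(Br)cc2)C(N)=N1`: 350 nM
- compound 3 `NC1=NC2(CCOCC2)N(OCCCOc2ccc(Br)cc2)C(N)=N1`: 310 nM

The three measured numbers lie close together, all within the usual scatter of one another, so none can be called stronger or weaker than the others. Compound 2 and compound 3 share the same side chain and differ only in their cores; how the two cores differ is not broken down here. Going from compound 2 to compound 1, the change is tert-butyl in place of bromo on an aromatic carbon, and this gave a 1.3-fold lower number from compound 2 to compound 1 (0.10 log units; within the scatter).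

Compound 4 `CC(C)(C)c1ccc(OCCCON2C(N)=NC(N)=NC23CCOCC3)cc1` has not yet been tested. It differs from compound 3 by tert-butyl in place of bromo on an aromatic carbon, the same change at the same place as the one already measured. In this assay compound 4 is therefore expected to sit near compound 3, with an estimated step of a 1.2-fold lower number from compound 3 to compound 4 (0.09 log units; within the scatter), because the measured step was a 1.3-fold lower number from compound 2 to compound 1 (0.10 log units; within the scatter). Compound 4 is expected to give about 250 nM, most likely between 120 nM and 520 nM.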

Compound 4, half-maximal inhibitory concentration: 870 nM
Estimate against measurement, compound 4: 3.5-fold (0.54 log units) below; measured number outside the range, above it.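

In this assay, tert-butyl in place of bromo gave a 2.8-fold higher number from compound 3 to compound 4 (0.45 log units; beyond the scatter), which means weaker inhibition on this core. Set beside the earlier step, the same change did not carry over from one core to the other: the same change on two cores in this assay, a 1.3-fold lower number (0.10 log units; within the scatter) from compound 2 to compound 1 and a 2.8-fold higher number (0.45 log units; beyond the scatter) from compound 3 to compound 4, 3.5-fold (0.55 log units) apart, beyond the scatter of two such steps. So in these two pairs the result of the change depends on the core it is made on, but two pairs cannot explain why, and they cannot predict what the change would do on any further core.

The compounds shown leave open whether other groups at the same place, such as methoxy or nitrile, would also give different results on the two cores. They also leave open whether a longer chain would keep this difference between the cores.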